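Trifluoromethylphenyl to Pyridinylmethyl on the Amine Nitrogen

The source may hold more compounds than are shown below. What is called first, only, known or untested is meant among the compounds shown, and "the series" means these compounds.

Measured so far in an ADME assay on RAW264.7 cells (Mus musculus) for cytotoxicity, read by MTT assay; on this read-out lower numbers stand for stronger inhibition and higher numbers for weaker inhibition:
compound 1 `COc1cc(/C=C/c2nc(Nc3ccc(C(F)(F)F)cc3)c3sccc3n2)cc(OC)c1OC` — > 50000 nM, a limit of the assay
compound 2 `COc1cc(/C=C/c2nc(NCc3ccc(Cl)cc3)c3sccc3n2)cc(OC)c1OC` — > 50000 nM, a limit of the assay

Compound 1 thus stands at the limit of this assay, where only a limit and no number is reported. Compound 2 sits at that same limit. The step that the two limits leave unreadable from compound 1 to compound 2 therefore cannot be given a size. The unmeasured compound 3 `COc1cc(/C=C/c2nc(NCc3ccncc3)c3sccc3n2)cc(OC)c1OC` differs from compound 1 by (pyridin-4-yl)methyl in place of 4-(trifluoromethyl)phenyl on a nitrogen on an aromatic ring. Within the data shown here, the only measured step that bears on this change is a step that the two limits leave unreadable from compound 1 to compound 2, which alters the same nitrogen; both of its values sit where the limit of > 50000 nM in this assay, at which 2 of the 2 values shown sit, shows. No readable step exists, so compound 3 is expected to stay at the limit as well, with a step that the limit leaves unreadable from compound 1 to compound 3 that means no change the assay can show. Compound 3 is estimated at 60000 nM, in the range 25000 nM to 150000 nM.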

Compound 3, half-maximal inhibitory concentration: > 50000 nM
Compound 3 was reported as a limit (the forecaster's own chance of this, stated with the estimate: 85%); the middle value lies beyond the limit too.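

Compound 1, compound 2 and compound 3 all stop at one limit in this assay, so none of the steps among them can be read: the limit of > 50000 nM in this assay, at which 3 of the 3 values shown sit. The compounds shown leave open whether any group on this nitrogen would give a measured number rather than a limit.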